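Hydroxyl Position and Cytotoxicity Across Two Related Cores

The compounds below may be only part of what the source reports. "The series", "measured", "known", "first", "only" and "open" are said of these compounds alone.

Compound 1 `Oc1ccc(-c2cc(-c3ccco3)cc(-c3ccccc3O)n2)cc1`: > 50000 nM (a limit of the assay).
Compound 2 `Oc1ccc(-c2cc(-c3ccco3)cc(-c3cccc(O)c3)n2)cc1`: 2070 nM.
Compound 3 `Oc1ccccc1-c1cc(-c2ccoc2)cc(-c2ccccc2O)n1`: > 50000 nM (a limit of the assay).

In a functional assay on DU-145 cells (Homo sapiens) for cytotoxicity, read by CCK-8 assay (a higher number here means a weaker inhibitor, a lower number a stronger inhibitor), compound 1 gives > 50000 nM, which is a limit rather than a number. Compound 2 gives 2070 nM. The step of an at least 24-fold lower number from compound 1 to compound 2 (1.38 log units; beyond the scatter) comes with the change (3-hydroxyphenyl in place of 2-hydroxyphenyl on an aromatic carbon). Compound 3 gives > 50000 nM, again a limit. How the core of compound 3 differs from that of compound 1 is not broken down here. Compound 4 `Oc1cccc(-c2cc(-c3ccoc3)cc(-c3ccccc3O)n2)c1` differs from compound 3 by 3-hydroxyphenyl in place of 2-hydroxyphenyl on an aromatic carbon, the same kind of change as before, though here the place is meta to a 2-hydroxyphenyl group and meta to a furan-3-yl group rather than meta to a 4-hydroxyphenyl group and a furan-2-yl group. Because compound 3 sits at the limit (the limit of > 50000 nM in this assay, at which 2 of the 3 values shown sit), the size of the expected step for compound 4 in this assay cannot be fixed from compound 3 alone and rests on the step of an at least 24-fold lower number from compound 1 to compound 2 (1.38 log units; beyond the scatter). For compound 4 the expected step is an at least 8.3-fold lower number from compound 3 to compound 4 (0.92 log units; beyond the scatter). Compound 4 is estimated at 6000 nM, within 1500 nM to 50000 nM.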

Compound 4, half-maximal inhibitory concentration: 2790 nM
Compound 4: the middle estimate sits 2.2-fold (0.33 log units) above what was measured, within the range that was stated.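

In this assay, 3-hydroxyphenyl in place of 2-hydroxyphenyl brings an at least 17-fold lower number from compound 3 to compound 4 (1.25 log units; beyond the scatter), so the change points the same way on the core of compound 3 as on the core of compound 1. The two steps can be set side by side: the same change on two cores in this assay, an at least 24-fold lower number (1.38 log units; beyond the scatter) from compound 1 to compound 2 and an at least 17-fold lower number (1.25 log units; beyond the scatter) from compound 3 to compound 4; the limit leaves it open whether they differ. Both steps start from a limit, and the data fix the exact size of neither step and do not show that the two cores respond equally: the limit of > 50000 nM in this assay, at which 2 of the 4 values shown sit.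

The compounds shown leave open whether the hydroxyl itself is needed on the 3-hydroxyphenyl group. An amine or a carboxylic acid in its place might keep or lose the cytotoxicity seen with compound 4.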